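What a boron-containing group may do to compound 3

The source may hold more compounds than are shown below. What is called first, only, known or untested is meant among the compounds shown, and "the series" means these compounds.

Compound 1 `COc1ccc(-c2ccccc2C(=O)/C=C/c2ccc(F)cc2)cc1OC` gives 8600 nM
Compound 2 `COc1ccc(OC)c(/C=C/C(=O)c2ccccc2-c2ccc(OC)c(OC)c2)c1` gives 4100 nM
Compound 3 `COc1ccc(/C=C/C(=O)c2ccccc2-c2ccc(F)cc2)cc1` gives 140 nM

In a functional assay on A549 cells (Homo sapiens) for antiproliferative activity, read by sulforhodamine B assay, with a stated time of 48 h (a higher number here means a weaker inhibitor, a lower number a stronger inhibitor), compound 3 has the lowest of the three numbers, beyond the scatter from both others, which makes it the strongest inhibitor of this small set. Compound 4 `COc1ccc(/C=C/C(=O)c2ccccc2-c2ccc(F)cc2)cc1B(O)O` keeps compound 3 intact except at one place: a group of 3 heavy atoms (1 boron, 2 oxygen; no ring) in place of a hydrogen atom, on an aromatic carbon. The new group sits on an aromatic carbon of a six-membered aromatic ring of carbon only, ortho to a methoxy group and meta to a large group.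

For the measured compounds named here, only one measured step exists, a 2.1-fold lower number from compound 1 to compound 2 (0.32 log units; beyond the scatter), and it is modest. Going by the values given here, it replaces a different group, on the chain, so it offers only weak guidance, and no measured pair tests this aromatic carbon. The values do spread widely, with compound 1 at 8600 nM and compound 3 at 140 nM, so a sizeable shift cannot be ruled out. Since compound 3 already holds the lowest number, a weaker result seems somewhat more likely than a stronger one. The estimated change is a 2.1-fold higher number from compound 3 to compound 4 (0.33 log units; beyond the scatter), and it is an uncertain one. For compound 4 the expected value is 300 nM, with an estimated range from 40 nM to 2500 nM.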

Compound 4, half-maximal inhibitory concentration: 82 nM
For compound 4 the middle estimate is 3.7-fold (0.56 log units) above the measured one; the range from low to high includes it.
By their numbers in this assay, from the lowest: compounds 4 and 3 (each within the scatter of the next); then compound 2; then compound 1.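

In this assay, the step that puts the boron-containing group on this aromatic carbon reads a 1.7-fold lower number from compound 3 to compound 4 (0.23 log units; within the scatter) and therefore gives no sign of a real difference between the two compounds. For the compounds shown here, until now no measured pair tested this carbon, and this one shows that a hydrogen atom here can give way to a group of 3 heavy atoms with 2 hydrogen-bond donors and 2 hydrogen-bond acceptors while the number stays within the scatter of that of compound 3, so the position, ortho to a methoxy group and meta to a large group, accepts at least this one larger group in this cell test. No measurement shown here offers an explanation for this outcome.

As far as these compounds go, whether a carboxylic acid, an amine or a simple hydroxyl group on the same carbon would also stay within the scatter of compound 3 remains open, and with it whether the boron atom matters or any group of similar size would do. Also open, from the compounds shown here alone, is whether the boron-containing group would give a similar result on the other compounds, such as compound 1, where the groups elsewhere on the shared core differ.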